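Aromatic methoxy to hydroxy across two related cores

This account rests on a few compounds, and the source may have more. Where it says the series, first, only, none or still open, it means among the compounds named here.

Compound 1 `COc1ccc(C(=O)O[C@H]2C=C(C)C(=O)C[C@@]3(C)CC[C@@](O)(C(C)C)[C@H]23)cc1` and compound 2 `CC1=C[C@H](OC(=O)c2ccc(O)cc2)[C@@H]2[C@](C)(CC[C@@]2(O)C(C)C)CC1=O` share one core and differ only by hydrogen in place of methyl on an oxygen on an aromatic ring. In a functional assay on Jurkat cells (Homo sapiens) for cytotoxicity, read by MTT assay, with a stated time of 72 h (on this read-out higher numbers stand for weaker inhibition and lower numbers for stronger inhibition), compound 1 gives 40500 nM and compound 2 gives 40500 nM, so the step of no change at the digits printed from compound 1 to compound 2 (within the scatter). Compound 3 `COc1ccc(C(=O)O[C@H]2CC(C)=CC[C@@]3(C)CC[C@@](O)(C(C)C)[C@H]23)cc1` carries a second core; how it differs from compound 1 is not broken down here. In this assay compound 3 gives 30500 nM, and the values of compound 1, compound 2 and compound 3 all lie within the scatter of one another, so no order among them is drawn. Compound 4 `CC1=CC[C@@]2(C)CC[C@@](O)(C(C)C)[C@@H]2[C@@H](OC(=O)c2ccc(O)cc2)C1` is the unmeasured partner of compound 3, reached by hydrogen in place of methyl on an oxygen on an aromatic ring, the same change as that made between compound 1 and compound 2, the place reading alike word for word in both pairs. For the measured compounds named here, the single measured instance of this change shows no shift, so the expectation for compound 4 rests on the value of compound 3 30500 nM and on the step of no change at the digits printed from compound 1 to compound 2 (within the scatter). In this assay compound 4 is expected to give about 30500 nM, within a range of 15000 nM to 62000 nM. Compound 4 is thus expected to show a step of no change at the digits printed from compound 3 to compound 4 (within the scatter), essentially none.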

Compound 4, half-maximal inhibitory concentration: > 100000 nM
Compound 4: only a limit was reported (the forecaster's own chance of this, stated with the estimate: 10%); middle value at least 3.2-fold (0.51 log units) away from the limit.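

In this assay, methoxy to hydroxy on the core of compound 3 gives an at least 3.2-fold higher number from compound 3 to compound 4 (0.51 log units; beyond the scatter), so the result from the core of compound 1 did not carry over to this second core: the same change on two cores in this assay, no change at the digits printed (within the scatter) from compound 1 to compound 2 and an at least 3.2-fold higher number (0.51 log units; beyond the scatter) from compound 3 to compound 4, at least 3.2-fold (0.51 log units) apart, beyond the scatter of two such steps

Compound 4 is reported only as a limit and not as a number, so the size of its step stays open at one end: the limit of > 100000 nM in this assay, at which 1 of the 4 values shown sits.

These notes rest on one pair per core, which shows that this change cannot be assumed to transfer between these two cores, but does not give a general rule for either core or identify what in the cores sets the two steps apart.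

The compounds shown leave open how an amine or a carboxylic acid in place of the methoxy would read on either core in this assay, and likewise a longer chain such as ethoxy. Going by these compounds, whether the gap between the two cores persists with any such group also remains open.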